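The source may report more compounds than this note shows. Statements on the series, on what has been measured and on what is new or still open speak of the compounds shown alone.

Measured compounds in a functional assay on the whole organism (strain Wistar) for inhibition, with Rattus norvegicus as the target, read by paw edema, with stated times of 30 min and 60 min, at a dose of 50 mg/kg by the oral route; on this read-out higher numbers stand for more inhibition at the one dose given (going by the name of the read-out) and lower numbers for less inhibition:
- compound 1 `Fc1ccc(C2=NN(c3ccccc3)C(c3cn(-c4ccccc4)nc3-c3ccc(Cl)c(Cl)c3)C2)cc1`: 55.7%
- compound 2 `O=CN1N=C(c2ccc(Cl)cc2)CC1c1cn(-c2ccccc2)nc1-c1ccc(Cl)c(Cl)c1`: 51.1%
- compound 3 `Clc1ccc(C2=NNC(c3cn(-c4ccccc4)nc3-c3ccc(Cl)c(Cl)c3)C2)cc1`: 45.8%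

Compound 3 gives the lowest of the three numbers in this assay, but both gaps to it fall within the scatter: compound 2 sits a number 5.3 percentage points lower from compound 2 to compound 3 (within the scatter), and compound 1 stands only a little higher still. Nothing among the three separates from the rest.

Compound 4 `Clc1ccc(C2=NN(c3ccccc3)C(c3cn(-c4ccccc4)nc3-c3ccc(Cl)c(Cl)c3)C2)cc1` is not yet measured. It differs from compound 3 in one place: phenyl in place of hydrogen on an amine nitrogen in a ring. Within the data shown here, the only measured step at that same ring nitrogen is the exchange of formyl for hydrogen, a number 5.3 percentage points lower from compound 2 to compound 3 (within the scatter), which changed nothing beyond the scatter. Compound 1, which carries a phenyl on that nitrogen together with a 4-fluorophenyl group in place of the 4-chlorophenyl group, gives 55.7%, a number close to that of compound 3.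

On that basis the step of a number 7.2 percentage points higher from compound 3 to compound 4 (within the scatter) is expected to stay within the scatter, leaning, if anything, slightly upward. Compound 4 is therefore estimated at 53%, with a range from 43% to 63%.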

Compound 4, a percentage reported as inhibition, in the whole organism at one dose (the size of the read-out at that dose, not a potency): 53.4%
The estimate for compound 4 lay 0.4 percentage points below the measured number; the range from low to high includes it.
By their numbers in this assay, from the lowest: compounds 3, 2, 4 and 1 (each within the scatter of the next).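

In this assay the amine nitrogen in a ring can now be read with the 4-chlorophenyl group held constant: phenyl in place of hydrogen (a number 7.6 percentage points higher from compound 3 to compound 4 (within the scatter)) and phenyl in place of formyl (a number 2.3 percentage points higher from compound 2 to compound 4 (within the scatter)) both stay within the scatter, so hydrogen, formyl and phenyl do not separate at this position. Among these compounds, with phenyl on that nitrogen, chloro in place of fluoro on an aromatic carbon (a number 2.3 percentage points lower from compound 1 to compound 4 (within the scatter)) gives the first direct reading of this exchange, and it also stays within the scatter. No measurement bears on why these groups are not told apart here.

From the compounds shown here alone, whether an acetyl or a 4-methoxyphenyl group on the same nitrogen would move the number beyond the scatter remains open. Also open, going by these compounds, is whether a carboxylic acid or an amine on that nitrogen would do so.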